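The source may hold more compounds than are shown below. What is called first, only, known or untested is meant among the compounds shown, and "the series" means these compounds.

Measured compounds: compound 1 `Cc1ccc(-c2cc(C(=O)N3CCC4(CC3)CC(=O)c3nn(C(C)(C)C)cc3O4)c3ccccc3n2)cc1` gives 5300 nM in a functional assay on A549 cells (Homo sapiens) for inhibition, read by MTT assay, with a stated time of 72 h; on this read-out higher numbers stand for weaker inhibition and lower numbers for stronger inhibition; compound 2 `CC(C)(C)n1cc2c(n1)C(=O)CC1(CCN(C(=O)c3cc(-c4ccccc4Cl)nc4ccccc34)CC1)O2` gives 2180 nM.

Compound 2 has the lowest of the two numbers shown; the only neighbour is compound 1, and the step of a 2.4-fold lower number from compound 1 to compound 2 (0.39 log units; beyond the scatter) separates them. Compound 3 `COc1ccc(-c2cc(C(=O)N3CCC4(CC3)CC(=O)c3nn(C(C)(C)C)cc3O4)c3ccccc3n2)cc1` is not yet measured. The change from compound 2 to compound 3 is 4-methoxyphenyl in place of 2-chlorophenyl on an aromatic carbon. Among the compounds with values here, the one measured step that bears on this is a 2.4-fold lower number from compound 1 to compound 2 (0.39 log units; beyond the scatter), where a para-substituted phenyl went to 2-chlorophenyl; the present change runs the other way, from 2-chlorophenyl back to a para-substituted phenyl, with 4-methoxyphenyl rather than 4-methylphenyl. The expectation is therefore a higher number, with a step of a 2.1-fold higher number from compound 2 to compound 3 (0.31 log units; beyond the scatter) of about the size seen before. Compound 3 is estimated at 4500 nM, within a range of 2000 nM to 10000 nM.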

Compound 3, half-maximal inhibitory concentration: 3740 nM
Estimate against measurement, compound 3: 1.2-fold (0.08 log units) above; the measured number falls inside the stated range.
By their numbers in this assay, from the lowest: compounds 2, 3 and 1 (each within the scatter of the next, the first and the last beyond it).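

In this assay, both a 1.7-fold higher number from compound 2 to compound 3 (0.23 log units; within the scatter) and a 1.4-fold lower number from compound 1 to compound 3 (0.15 log units; within the scatter) stay within the usual scatter, so the printed numbers do not separate 4-methoxyphenyl from either 2-chlorophenyl or 4-methylphenyl at this position next to the ring nitrogen. The single difference beyond the scatter is still a 2.4-fold lower number from compound 1 to compound 2 (0.39 log units; beyond the scatter), which means that swapping methyl for methoxy on the phenyl ring gives no readable change, and the three compounds show no trend across these aryl groups. Nothing given here accounts for these numbers.

The compounds shown leave open whether a plain phenyl, a pyridyl ring or a phenyl carrying a dimethylamino group would differ beyond the scatter at this position. They also leave open what a carboxylic acid on this phenyl ring would do.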